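This account rests on a few compounds, and the source may have more. Where it says the series, first, only, none or still open, it means among the compounds named here.

In a functional assay, read by spectrophotometry, with a stated time of 6 min (on this read-out lower numbers stand for an effect already at smaller amounts and higher numbers for an effect only at larger amounts of compound), three compounds have been measured so far. Compound 1 (`COc1c(C)cc(O)cc1/C=C/C(C)(O)CC(=O)/C=C(\C)CCCC(C)C(=O)/C=C/C(C)(C)O`) gives 24400 nM, compound 2 (`COc1c(C)cc(O)cc1/C=C/C(C)(O)CC(=O)/C=C(\C)CCCC(C)=O`) gives 44700 nM, and compound 3 (`COc1c(C)cc(O)cc1C/C=C(\C)CC(=O)/C=C(/C)CCCC(C)C(=O)/C=C/C(C)(C)O`) gives 26300 nM. The number for compound 3 lies within the scatter of both other numbers, so the three values show no order among themselves.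

Compound 4 (`COc1c(C)cc(O)cc1C/C=C(\C)CC(=O)/C=C(\C)CCCC(C)C(=O)/C=C/C(C)(C)O`) has not yet been measured. It has the same atoms and bonds as compound 3, and the only difference is the drawn configuration of one double bond: the two compounds have the same atoms and bonds; at least one stereo element is drawn with a configuration in one of them and without one in the other: 1 of 4 stereo elements differ; a double bond is drawn Z in compound 3 and E in compound 4. A double bond drawn Z in compound 3 is drawn E in compound 4.

Among the compounds with values here, only one measured step bears on this at all, and only indirectly. That step, a 1.8-fold higher number from compound 1 to compound 2 (0.26 log units; within the scatter), puts acetyl in place of a much larger chain group and still stays within the scatter. Within the data shown here, no measured pair isolates a change of double bond configuration, so the data offer no direct precedent and no direction for such a change.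

On this limited evidence, the expected outcome is a 1.0-fold lower number from compound 3 to compound 4 (0.00 log units; within the scatter), with no shift beyond the scatter anticipated. For compound 4 the estimated value is 26000 nM, with an expected range from 11000 nM to 60000 nM.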

Compound 4, half-maximal effective concentration: 24500 nM
Compound 4: the middle estimate sits 1.1-fold (0.03 log units) above what was measured; the range from low to high includes it.
By their numbers in this assay, from the lowest: compounds 1, 4, 3 and 2 (each within the scatter of the next).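

In this assay, within the data shown here, the change of this one double bond from Z to E gives a 1.1-fold lower number from compound 3 to compound 4 (0.03 log units; within the scatter), so the first measured pair to isolate a double bond configuration shows no shift beyond the scatter at this position. The earlier step, a 1.8-fold higher number from compound 1 to compound 2 (0.26 log units; within the scatter), concerned the exchange of a chain group and could say nothing about geometry; now a change of geometry and a change of group have both been read, and neither step leaves the scatter. This reading of the configuration carries a caveat, which limits how firmly the Z and E labels can be taken: the fact that one of compounds 3 and 4 is drawn with a defined configuration and the other without, at the place where they differ.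

The compounds shown leave open whether the configuration of the other double bonds, or of the stereo element at the carbon bearing the hydroxyl group in compounds 1 and 2, would matter in the same assay. They also leave open whether a carboxylic acid or an amine in place of the acetyl on that saturated chain carbon, or a longer chain there, would move the number beyond the scatter.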